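Replacing phenoxy with bromo on an aromatic carbon

This account rests on a few compounds, and the source may have more. Where it says the series, first, only, none or still open, it means among the compounds named here.

Compound 1 `COc1ccc(NC(=S)Nc2ccc3[nH]ccc3c2)cc1` and compound 2 `S=C(Nc1ccc(Oc2ccccc2)cc1)Nc1ccc2[nH]ccc2c1` share one core and differ in a single place. In an ADME assay on CHO-K1 cells (Cricetulus griseus) for cytotoxicity, read by MTT assay, with a stated time of 24 h (on this read-out higher numbers stand for lower toxicity in this test and lower numbers for higher toxicity in this test), compound 1 gives 476000 nM and compound 2 gives 36000 nM. Compound 2 thus holds the lower of the two numbers. Among the compounds with values here, the only measured step is a 13-fold lower number from compound 1 to compound 2 (1.12 log units; beyond the scatter), a large one, which came with phenyl in place of methyl on an oxygen on an aromatic ring.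

Compound 3 `S=C(Nc1ccc(Br)cc1)Nc1ccc2[nH]ccc2c1` keeps the core and carries bromo in place of phenoxy on an aromatic carbon. The phenyl ring that sets compound 2 apart from compound 1 is therefore gone again. Within the data shown here, the measured step bears on this change only in part, as no measured compound carries bromo. The expectation rests on a 13-fold lower number from compound 1 to compound 2 (1.12 log units; beyond the scatter) and is for a partial return towards the higher number, in a step smaller than that one. The expected change is a 3.1-fold higher number from compound 2 to compound 3 (0.49 log units; beyond the scatter). The estimate for compound 3 in this assay is 110000 nM, with an expected range of 35000 nM to 350000 nM.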

Compound 3, concentration lethal to 50% of the cells: 220000 nM
Estimate against measurement, compound 3: 2.0-fold (0.30 log units) below; low and high end bracket the measured number.
By their numbers in this assay, from the lowest: compound 2; then compound 3; then compound 1.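

At this position on the aromatic ring, bromo in place of phenoxy gives a 6.1-fold higher number from compound 2 to compound 3 (0.79 log units; beyond the scatter) in this assay, so the low number of compound 2 does not carry over to a group of one heavy atom without a ring. The return is only partial, however, as bromo in place of methoxy gives a 2.2-fold lower number from compound 1 to compound 3 (0.34 log units; beyond the scatter), which shows that the number at this position can also fall without a phenyl ring being present. Nothing available here accounts for either step.

Three groups at one position are too few to establish a trend across substituents, and the compounds shown do not separate the loss of the aromatic ring from the loss of the oxygen, since bromo differs from phenoxy in both. From the compounds shown here alone, it remains open where fluoro, chloro, an amine or a carboxylic acid on this carbon would fall in this assay, and whether a phenyl ring attached directly or through a longer chain, as in benzyloxy, would give a number close to that of compound 2.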